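Swapping fluoro for methyl on the sulfonamide aryl ring

The compounds below may be only part of what the source reports. "The series", "measured", "known", "first", "only" and "open" are said of these compounds alone.

Measured compounds:
compound 1 `O=C1O[C@H]([C@@H](O)Cn2cc(CNS(=O)(=O)c3ccc(F)cc3)nn2)C(OCc2ccccc2)=C1OCc1ccccc1` — 26800 nM
compound 2 `O=C1O/C(=C\Cn2cc(-c3cccc(O)c3)nn2)C(OCc2ccccc2)=C1OCc1ccccc1` — 27800 nM

In a functional assay on MCF7 cells (Homo sapiens) for antiproliferative activity, read by MTT assay, with a stated time of 72 h (a higher number here means a weaker inhibitor, a lower number a stronger inhibitor), compound 1 gives 26800 nM and compound 2 gives 27800 nM; the two numbers sit within the scatter of each other, so neither can be called stronger. Compound 3 `Cc1ccc(S(=O)(=O)NCc2cn(C[C@H](O)[C@H]3OC(=O)C(OCc4ccccc4)=C3OCc3ccccc3)nn2)cc1` differs from compound 1 by methyl in place of fluoro on an aromatic carbon. Among the compounds with values here, with no measured step of this kind to lean on, the expected change from compound 1 to compound 3 in this assay is a 1.1-fold lower number from compound 1 to compound 3 (0.03 log units; within the scatter), that is, none beyond the scatter. Compound 3 is therefore estimated at 25000 nM, with a likely range from 10000 nM to 60000 nM.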

Compound 3, half-maximal inhibitory concentration: 6400 nM
Compound 3: the middle estimate sits 3.9-fold (0.59 log units) above what was measured; measured number outside the range, below it.
By their numbers in this assay, from the lowest: compound 3; then compounds 1 and 2 (each within the scatter of the next).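

Replacing 4-fluorophenyl with 4-methylphenyl gives a 4.2-fold lower number from compound 1 to compound 3 (0.62 log units; beyond the scatter) in this assay, showing that the read-out responds to this one ring position, even though a single heavy atom is exchanged and no hydrogen-bond donor or acceptor is added or lost. Nothing measured here accounts for this step. The compounds shown leave open how other groups at this position, such as chloro, methoxy, ethyl or an amine, would compare with methyl, and whether a longer chain would lower the number further.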